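The compounds below may be only part of what the source reports. "The series", "measured", "known", "first", "only" and "open" are said of these compounds alone.

Compound 1, `COc1ccc(-c2cc(C(=O)O)sc2-c2cc(OC)c(OC)c(OC)c2)cc1[N+](=O)[O-]`, gives 38100 nM in a functional assay on HT-1080 cells (Homo sapiens) for antiproliferative activity, read by MTT assay, with a stated time of 72 h; on this read-out higher numbers stand for weaker inhibition and lower numbers for stronger inhibition. Compound 2, `COc1ccc(-c2cc(C(=O)O)sc2-c2cc(OC)c(OC)c(OC)c2)cc1OCc1ccccc1`, gives > 100000 nM in this assay, and this is a limit of the assay, not a number. Compound 2 thus stands only at the limit of > 100000 nM in this assay, at which 1 of the 2 values shown sits, with no measured potency of its own.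

Compound 3, `COc1ccc(-c2ccsc2-c2cc(OC)c(OC)c(OC)c2)cc1OCc1ccccc1`, keeps the rest of compound 2 and loses one group: hydrogen in place of carboxy on an aromatic carbon. In words, this is hydrogen in place of carboxy on an aromatic carbon, next to the ring sulfur.

Among the compounds with values here, only one measured step comes into play, an at least 2.6-fold higher number from compound 1 to compound 2 (0.41 log units; beyond the scatter), which was benzyloxy in place of nitro on an aromatic carbon. It leaves the carboxy group untouched, so it offers no direct measure of this change and serves only as a rough guide to size. A rise could not be read as a number in this assay, so the step that can be expected to register is a fall, of uncertain size but beyond the scatter.

The expected change is an at least 6.6-fold lower number from compound 2 to compound 3 (0.82 log units; beyond the scatter). For compound 3 the estimate is 15000 nM, with an expected range of 2000 nM to 80000 nM.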

Compound 3, half-maximal inhibitory concentration: > 100000 nM
Compound 3 ended at the assay's limit; the forecaster's own chance of this, stated with the estimate: 25%; at least 6.6-fold (0.82 log units) between middle value and limit.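

In this assay compound 3 gives > 100000 nM, which is a limit of the assay and not a number. Within the data shown here, compound 2 stands at the same limit, so no step between compound 2 and compound 3 can be read: the limit of > 100000 nM in this assay, at which 2 of the 3 values shown sit. The compounds shown leave open what hydrogen in place of carboxy does in a compound with a readable number.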